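Working notes on compounds 1 to 3 of the series

The source may hold more compounds than are shown below. What is called first, only, known or untested is meant among the compounds shown, and "the series" means these compounds.

Measured so far:
compound 1, `C=CCn1c(=O)n(CCC(CCOCc2ccccc2)CCOCc2ccccc2)c2nc(N)nc(O)c21`: 68%
compound 2, `CCOC(=O)Cn1c(=O)n(C2OC(CO)[C@@H](O)[C@H]2O)c2nc(N)nc(O)c21`: 86%

Both numbers come from a functional assay on the whole organism (B cells) with Mus musculus as the target; a lower number here means a smaller maximal response, a higher number a larger maximal response. Compound 2 stands highest of the two; compound 1 lies below it by a gap that exceeds the usual scatter of repeated measurements. Among the measured compounds shown here, no pair of measured compounds differs in a single place, so no step of known size exists to lean on.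

Compound 3, `NCC(O)Cn1c(=O)n(C2OC(CO)[C@@H](O)[C@H]2O)c2nc(N)nc(O)c21`, has not been measured. It differs from compound 2 in one place: 2-amino-1-hydroxyethyl in place of ethoxycarbonyl on a saturated chain carbon bound to an aromatic nitrogen. Nothing measured in the series bears on this exchange, so any expectation rests on compound 2 alone, whose maximal response in this assay was 86%. The expected change, a number 6 percentage points lower from compound 2 to compound 3 (within the scatter), is small and most likely downward, and may well be no larger than the scatter. Compound 3 is accordingly estimated at 80% in this assay, with a range from 62% to 98% expected to cover most repeat measurements.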

Compound 3, largest response reached (reported as maximal response), in percent of the reference or control that the assay uses: 110%
Compound 3: the middle estimate sits 30 percentage points below what was measured, and the stated range ends below it.
By their numbers in this assay, from the lowest: compound 1; then compound 2; then compound 3.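

In this assay, among the compounds shown here, 2-amino-1-hydroxyethyl in place of ethoxycarbonyl on a saturated chain carbon bound to an aromatic nitrogen gives a number 24 percentage points higher from compound 2 to compound 3 (beyond the scatter) and so provides the first step of known size, showing that the maximal response depends on the group carried at this position. The exchange replaces a group with 0 hydrogen-bond donors and 1 double bond outside aromatic rings by one with 2 hydrogen-bond donors and no such double bond, while the sugar-bearing side of the molecule stays the same. Nothing available on these compounds accounts for the size or direction of this step.

The amine and the hydroxyl enter together, so the step cannot be divided between them; a 2-hydroxyethyl group, a 2-aminoethyl group or a carboxylic acid at the same place would be needed to separate the contributions of the amine, the hydroxyl and the ester. Also open, from the compounds shown here alone, is whether the same exchange gives a step of similar size with the other substituent of compound 1 on the shared core, or with a longer chain ending in the amine.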